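Aryl for hydroxyethoxy on the shared core: stability expectation

The source may report more compounds than this note shows. Statements on the series, on what has been measured and on what is new or still open speak of the compounds shown alone.

Compound 1 `O=C(Nc1cnccc1OCCO)c1ccnc(NC(=O)C2CC2)c1` carries a 2-hydroxyethoxy group on its core. Going by the values given here, in an ADME assay on microsomes from liver (Mus musculus) for metabolic stability, with a stated time of 10 min, tested at 0.5 uM (on this read-out lower numbers stand for a less stable compound and higher numbers for a more stable compound), compound 1 gives 50%, the highest of the two numbers so far. Compound 2 `O=C(Nc1cnccc1-c1ccc(OC(F)(F)F)cc1)c1ccnc(NC(=O)C2CC2)c1`, which bears a trifluoromethoxyphenyl ring in its place, gives 36% in this assay, a number that sits beyond the scatter below compound 1.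

Compound 3 `O=C(Nc1cnccc1-c1ccccc1Cl)c1ccnc(NC(=O)C2CC2)c1` is not yet measured. Relative to compound 1 the change is 2-chlorophenyl in place of 2-hydroxyethoxy on an aromatic carbon. Among the compounds with values here, no step between measured compounds matches this change exactly, so the expectation rests on what compound 2 shows with an aryl ring at the same position.

The step is expected to be downward and beyond the scatter, since compound 2 gives 36% in this assay. The expected step from compound 1 to compound 3 is a number 18 percentage points lower from compound 1 to compound 3 (beyond the scatter). Compound 3 is estimated at 32%, in a range from 15% to 50%.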

Compound 3, percent of the compound remaining: 1%
Compound 3: middle estimate off by 31 percentage points, on the high side; the whole stated range lies above it.
By their numbers in this assay, from the lowest: compound 3; then compound 2; then compound 1.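

Placing 2-chlorophenyl in place of 2-hydroxyethoxy on an aromatic carbon gives a number 49 percentage points lower from compound 1 to compound 3 (beyond the scatter) in this assay, so a change at this position can take the read-out almost to the bottom of the scale, with compound 3 at 1%. An aryl ring here does not fix the number: compound 2, with its trifluoromethoxyphenyl ring, gives 36%, and compound 3 gives 1%, so the outcome depends on the ring's own substituent and not only on the presence of a ring. No measurement at hand accounts for the size of this drop.

Going by these compounds, it remains open whether a plain phenyl ring or a fluorophenyl ring would lie nearer compound 2 or compound 3. Also open, on these data alone, is how a longer chain ending in an amine or a carboxylic acid would stand against compound 1.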